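The compounds below may be only part of what the source reports. "The series", "measured", "known", "first", "only" and "open" are said of these compounds alone.

Three analogues share one core and differ only in the aryl group carried on an aromatic nitrogen. Compound 1 `COc1cc(/C=C/C(C)=O)ccc1OCc1cn(-c2c(F)cccc2F)nn1` gives 24200 nM in a functional assay on PC-3 cells (Homo sapiens) for antiproliferative activity, read by MTT assay, with a stated time of 48 h; a higher number here means a weaker inhibitor, a lower number a stronger inhibitor. Compound 2 `COc1cc(/C=C/C(C)=O)ccc1OCc1cn(-c2ccccc2CO)nn1` gives 50300 nM in this assay. Compound 3 `COc1cccc(-n2cc(COc3ccc(/C=C/C(C)=O)cc3OC)nn2)c1` gives 31600 nM in this assay, a number that sits within the scatter of compound 1 and of compound 2 alike, so compound 3 cannot be set apart from either of them. For the measured compounds named here, the only exchange among the three that reaches beyond the scatter is a 2.1-fold higher number from compound 1 to compound 2 (0.32 log units; beyond the scatter), and even that is modest.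

The next compound, compound 4 `COc1cc(/C=C/C(C)=O)ccc1OCc1cn(-c2ccccc2Cl)nn1`, is reached from compound 3 by a change in the same position: 2-chlorophenyl in place of 3-methoxyphenyl on an aromatic nitrogen. Going by the values given here, the steps that bear on this change are the earlier aryl exchanges on the aromatic nitrogen, namely a 1.3-fold higher number from compound 1 to compound 3 (0.12 log units; within the scatter) and a 1.6-fold lower number from compound 2 to compound 3 (0.20 log units; within the scatter), both within the scatter, together with the modest 2.1-fold higher number from compound 1 to compound 2 (0.32 log units; beyond the scatter). Every such exchange so far has moved this assay little, and on that basis the step of a 1.2-fold lower number from compound 3 to compound 4 (0.07 log units; within the scatter) is expected to stay within the scatter, with no clear direction. Compound 4 is therefore estimated at 27000 nM in this assay, with a range from 12000 nM to 60000 nM.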

Compound 4, half-maximal inhibitory concentration: 48000 nM
For compound 4 the middle estimate is 1.8-fold (0.25 log units) below the measured one; measured number inside the range.
By their numbers in this assay, from the lowest: compounds 1, 3, 4 and 2 (each within the scatter of the next, the first and the last beyond it).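

Placing 2-chlorophenyl in place of 3-methoxyphenyl on the aromatic nitrogen gives a 1.5-fold higher number from compound 3 to compound 4 (0.18 log units; within the scatter), so in this assay this exchange of an aryl group counted with a hydrogen-bond acceptor for one counted without any leaves no readable difference. Chloro in place of hydroxymethyl on an aromatic carbon gives a 1.0-fold lower number from compound 2 to compound 4 (0.02 log units; within the scatter), the first comparison here in which only the group on the aryl ring changes, and compound 2 and compound 4 cannot be told apart. For the compounds shown here, the exchange for 2,6-difluorophenyl gives a 2.0-fold higher number from compound 1 to compound 4 (0.30 log units; within the scatter), so 2-chlorophenyl cannot be set apart from any of the three other aryl groups, and a 2.1-fold higher number from compound 1 to compound 2 (0.32 log units; beyond the scatter) remains the only single exchange beyond the scatter. Nothing available explains why these aryl groups read so much alike.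

The compounds shown leave open whether an aryl ring carrying an amine or a carboxylic acid would move this assay beyond the scatter. They also leave open whether a longer chain, such as a hexyl group, in place of the aryl group on the aromatic nitrogen would do so.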